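Moving one methyl group: the step to compound 4

The source may report more compounds than this note shows. Statements on the series, on what has been measured and on what is new or still open speak of the compounds shown alone.

In a functional assay on DU-145 cells (Homo sapiens) for inhibition, read by CCK-8 assay, with a stated time of 72 h (a lower number here means a stronger inhibitor, a higher number a weaker inhibitor), compound 3 (`Cc1ccc(NS(=O)(=O)c2cccc(CCCCCCNC(=O)/C=C/c3cccnc3)c2)cc1`) gives 34.4 nM and stands level with compound 1 (`O=C(/C=C/c1cccnc1)NCCCCc1ccc(S(=O)(=O)Nc2ccccc2)cc1`) at 47.9 nM within the usual scatter. Compound 2 (`O=C(/C=C/c1cccnc1)NCCCCCCCc1ccc(S(=O)(=O)Nc2ccccc2)cc1`) gives 438 nM and lies beyond the scatter from compound 3. Compound 4 (`Cc1cccc(NS(=O)(=O)c2cccc(CCCCCCNC(=O)/C=C/c3cccnc3)c2)c1`) carries 3-methylphenyl in place of 4-methylphenyl on a sulfonamide nitrogen. Within the data shown here, no measured pair here shows this kind of change, so the direction stays open, and no step beyond the scatter is expected in this assay for so small a rearrangement. The expected move is a 1.2-fold higher number from compound 3 to compound 4 (0.07 log units; within the scatter) and nothing firmer. For compound 4 the estimated value is 40 nM with an expected range from 15 nM to 110 nM in this measurement.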

Compound 4, half-maximal inhibitory concentration: 41.7 nM
Estimate against measurement, compound 4: 1.0-fold (0.02 log units) below; measured number inside the range.
By their numbers in this assay, from the lowest: compounds 3, 4 and 1 (each within the scatter of the next); then compound 2.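

Among these compounds, this is the first matched pair at the sulfonamide nitrogen, and in this assay the swap of 4-methylphenyl for 3-methylphenyl gives a 1.2-fold higher number from compound 3 to compound 4 (0.08 log units; within the scatter) with the shared core unchanged. At this position, in this one pair, the two placements of the methyl group cannot be told apart. Nothing at hand bears on what lies behind this result.

The compounds shown leave open whether 2-methylphenyl, or a phenyl carrying an amine or a carboxylic acid, would give a similar number on this nitrogen. They also leave open whether the same swap would read alike on a longer chain.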